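The source may hold more compounds than are shown below. What is called first, only, known or untested is meant among the compounds shown, and "the series" means these compounds.

Values in a functional assay on SF-539 cells (Homo sapiens) for inhibition, read by sulforhodamine B assay, with a stated time of 48 h; a higher number here means a weaker inhibitor of growth, a lower number a stronger inhibitor of growth:

compound 1, `CCOC(=O)[C@H](CCC(=O)O)NC(=O)c1ccc(Oc2nc3cc(N)cc(N)c3nc2-c2ccccc2)cc1`: 33900 nM
compound 2, `Nc1cc(N)c2nc(-c3ccccc3)c(NCc3ccc(F)cc3)nc2c1`: 1820 nM
compound 3, `COc1ccc(Sc2nc3cc(N)cc(N)c3nc2-c2ccccc2)cc1`: 10000 nM

Among these three numbers compound 3 stands second highest in this assay. Compound 1 gives the highest number, 33900 nM, and compound 2 the lowest, 1820 nM; both gaps to compound 3 lie beyond the usual scatter.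

The step under consideration leads from compound 3 to compound 4, `Nc1cc(N)c2nc(-c3ccccc3)c(Oc3ccc(F)cc3)nc2c1`. The change is 4-fluorophenoxy in place of (4-methoxyphenyl)sulfanyl on an aromatic carbon. Among the measured compounds shown here, only one measured step touches the same place on the shared core: a 5.5-fold higher number from compound 2 to compound 3 (0.74 log units; beyond the scatter). That step exchanged a benzylic amine link for an aryl thioether and is therefore of limited bearing, since the present change keeps an aryl substituent but alters the linking atom and the para group. Compound 1 also carries an aryl ether at this position, yet its para group is quite different, so its number says little about compound 4 on its own.

For the measured compounds named here, with no measured pair isolating the linker exchange, a small step at most is expected, a 1.3-fold lower number from compound 3 to compound 4 (0.10 log units; within the scatter), likely within the scatter. Compound 4 is therefore estimated at 8000 nM in this assay, with a range from 2500 nM to 25000 nM.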

Compound 4, concentration for 50% growth inhibition: 18200 nM
Compound 4: middle estimate off by 2.3-fold (0.36 log units), on the low side; low and high end bracket the measured number.
By their numbers in this assay, from the lowest: compound 2; then compounds 3, 4 and 1 (each within the scatter of the next, the first and the last beyond it).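

In this assay, the exchange at this position gives a 1.8-fold higher number from compound 3 to compound 4 (0.26 log units; within the scatter), so an aryl ether carrying fluorine and an aryl thioether carrying methoxy cannot be told apart in this assay, even though both the linking atom and the substituent on the ring differ. The (4-fluorobenzyl)amino group separates more clearly, with a 10-fold higher number from compound 2 to compound 4 (1.00 log units; beyond the scatter), so compound 2 now stands apart from both of the compounds whose aryl ring is joined through a single oxygen or sulfur, and the same fluorinated ring does not by itself set the number. No measurement shown here explains this gap.

The compounds shown do not reveal whether the lower number of compound 2 goes with its nitrogen link or with the extra carbon between link and ring, a question that 4-fluoroanilino and 4-fluorobenzyloxy groups at this position would separate. Nor do they isolate the linking atom from the ring substituent in compound 3 and compound 4, which a (4-fluorophenyl)sulfanyl or a 4-methoxyphenoxy group would do.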